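From a Difluorophenyl Amide to a Dimethylthiazolyl Amide

The compounds below may be only part of what the source reports. "The series", "measured", "known", "first", "only" and "open" are said of these compounds alone.

Of the compounds shown here, three have been measured in a physicochemical assay for solubility, in phosphate buffer, measured as kinetic solubility, with a stated time of 1 h, at pH 7.4; a higher number here means a more soluble compound, a lower number a less soluble compound. Compound 1 `Cc1cc(C)cc(NC(=O)COc2cc(C)nc3ccccc23)c1` gives 55000 nM. Compound 2 `COc1ccc2nc(C)cc(OC(C)C(=O)Nc3cc(C)cc(C)c3)c2c1` gives 61000 nM in this assay. Compound 3 `COc1ccc2nc(C)cc(OCC(=O)Nc3cc(F)cc(F)c3)c2c1` gives 13000 nM in this assay, the lowest of the three numbers; the gap from compound 3 up to compound 1 is beyond the scatter, and the gap up to compound 2 is a little wider and also beyond the scatter.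

Compound 4 `COc1ccc2nc(C)cc(OCC(=O)Nc3nc(C)c(C)s3)c2c1` has not yet been measured in this assay. It differs from compound 3 in one place: 4,5-dimethyl-1,3-thiazol-2-yl in place of 3,5-difluorophenyl on an amide-type nitrogen. Among the measured compounds shown here, no pair of measured compounds shows this change, so its effect cannot be read off from a known step. What the data do show is that compound 3 stands at the bottom of the measured range, while compound 1 and compound 2, which carry different groups on the amide nitrogen, stand higher. On that basis a modest rise is expected rather than a fall, though a step no larger than the scatter would not surprise. The step estimated here, a 1.7-fold higher number from compound 3 to compound 4 (0.23 log units; within the scatter), is a small upward one. Compound 4 is therefore expected to give about 22000 nM in this assay, with a range from 6000 nM to 70000 nM.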

Compound 4, solubility: 31500 nM
Estimate against measurement, compound 4: 1.4-fold (0.16 log units) below; measured number inside the range.
By their numbers in this assay, from the lowest: compound 3; then compounds 4, 1 and 2 (each within the scatter of the next).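

Among the compounds shown here, this is the first step that can be read at a single place: with the rest of the structure unchanged, in this assay the change on the amide-type nitrogen gives a 2.4-fold higher number from compound 3 to compound 4 (0.38 log units; beyond the scatter) and so stands as a modest step beyond the scatter. It shows that this position alone can move the read-out, with 4,5-dimethyl-1,3-thiazol-2-yl, a five-membered aromatic ring with 2 hetero atoms and 2 hydrogen-bond acceptors, giving the higher number and 3,5-difluorophenyl, a six-membered aromatic ring of carbon only with 0 hydrogen-bond acceptors, the lower. No independent measurement bears on which part of this exchange accounts for the step.

Going by these compounds, it remains open whether the step belongs to the ring itself or to its two methyl groups, a question that an unsubstituted 1,3-thiazol-2-yl on the same nitrogen would address. On these data alone, it also remains open whether the same exchange would give a similar step on the core of compound 1 or in the setting of compound 2.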